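Buffer stability notes: two measured aryl analogues, one pending

The source may report more compounds than this note shows. Statements on the series, on what has been measured and on what is new or still open speak of the compounds shown alone.

compound 1 `C=CC(=O)Nc1cc(C(F)(F)F)cc(C(F)(F)F)c1` — 5.7 h
compound 2 `N#Cc1cc(C(F)(F)F)cc(C(F)(F)F)c1` — > 50 h, a limit of the assay

In an ADME assay for pharmacokinetics, read by LC-MS, in phosphate buffer, with a stated time of 72 h, at pH 7.4, tested at 250 uM (a lower number here means that the compound disappears faster, a higher number that the compound lasts longer), compound 1 gives 5.7 h. Compound 2 reaches only the limit of the assay, > 50 h, so it stands at the top end of the numbers shown (the limit of > 50 h in this assay, at which 1 of the 2 values shown sits). Within the data shown here, the single measured step is an at least 8.7-fold higher number from compound 1 to compound 2 (0.94 log units; beyond the scatter). Compound 3 `Fc1cc(C(F)(F)F)cc(C(F)(F)F)c1` follows from compound 2 by fluoro in place of cyano on an aromatic carbon. Among the measured compounds shown here, no measured step bears directly on this change: the one step available concerns a different group entering and leaving, and gives no guide to the exchange of a cyano for a fluoro. In this assay the step from compound 2 to compound 3 is therefore expected to be none beyond the scatter, a step that the limit leaves unreadable from compound 2 to compound 3. Compound 3 is estimated at 100 h, in the range 50 h to 300 h, and is expected most likely to be reported again only as a limit.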

Compound 3, half-life: > 50 h
Compound 3 ended at the assay's limit (the forecaster's own chance of this, stated with the estimate: 85%); the middle value lies beyond the limit too.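

The aromatic carbon meta to two trifluoromethyl groups now has a second replacement for (vinylcarbonyl)amino that moves the compound to the top of the range in this assay, with an at least 8.7-fold higher number from compound 1 to compound 3 (0.94 log units; beyond the scatter) as the readable step. Compound 3 gives > 50 h, a limit of the assay and not a number. The step between compound 2 and compound 3 cannot be read, and no order of cyano and fluoro can be given, only a shared ceiling: the limit of > 50 h in this assay, at which 2 of the 3 values shown sit.

The compounds shown leave open whether the shorter half-life of compound 1 belongs to the vinyl part of (vinylcarbonyl)amino, or would persist with a saturated propanoyl amide or a plain amine on this carbon. On these data alone, whether a carboxylic acid at this place would also reach the limit in this assay is equally open.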